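The source may hold more compounds than are shown below. What is called first, only, known or untested is meant among the compounds shown, and "the series" means these compounds.

Series notes. In an assay on isolated protein (Rattus norvegicus) for inhibition of carnitine palmitoyltransferase 1A (Sus scrofa) (a higher number here means a weaker inhibitor, a lower number a stronger inhibitor), compound 3 `CCCCCCCCCCCCCCC1(C(=O)OC)CO1` gives 300 nM, the lowest of the three numbers recorded. Compound 1 `CCCCC/C=C/CCCCCCCCCC1(C(=O)OC)CO1` gives 680 nM in this assay, and the step of a 2.3-fold lower number from compound 1 to compound 3 (0.36 log units; beyond the scatter) is modest. Compound 2 `CCCCCCC1(C(=O)OC)CO1` gives 136000 nM in this assay, so the two values of compound 2 and compound 3 show that a much shorter chain on the shared core goes with a far higher number. Compound 4 `CCCCCCCCCCCCC1(C(=O)OC)CO1` differs from compound 3 by hydrogen in place of ethyl on a saturated chain carbon, ten or more bonds along the chain from a saturated ring carbon. Going by the values given here, no measured step shortens this chain by two carbons alone; the gap between compound 2 and compound 3 points upward for any shortening. For compound 4 in this assay a higher number is expected, the step of a 3.3-fold higher number from compound 3 to compound 4 (0.52 log units; beyond the scatter), giving an estimate of 1000 nM with a range of 400 nM to 3000 nM.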

Compound 4, half-maximal inhibitory concentration: 600 nM
Beside the measured number, compound 4's estimate is 1.7-fold (0.22 log units) above it; the measured number falls inside the stated range.
By their numbers in this assay, from the lowest: compounds 3, 4 and 1 (each within the scatter of the next, the first and the last beyond it); then compound 2.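

In this assay, hydrogen in place of ethyl on a saturated chain carbon, ten or more bonds along the chain from a saturated ring carbon, gives a 2.0-fold higher number from compound 3 to compound 4 (0.30 log units; within the scatter), so this shortening cannot be told from repeat scatter. Hexyl in place of hydrogen, six bonds along the chain, gives a 230-fold lower number from compound 2 to compound 4 (2.36 log units; beyond the scatter), so the large change lies at the shorter end of the chain lengths shown. Propyl in place of hept-1-en-1-yl gives a 1.1-fold lower number from compound 1 to compound 4 (0.05 log units; within the scatter), so these two chains cannot be told apart here.

Nothing available explains how the number follows chain length. Going by these compounds, whether a longer chain, or a carboxylic acid in place of the methyl ester, holds the number at this level stays open.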